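A Triazolyl Group in Place of Pyridin-3-yl

A few compounds are considered here, and "the series" means these few. Any claim that something is new, unique, unknown or untested is made for them only; others in the source may bear on it.

In an ADME assay on SH-SY5Y cells (Homo sapiens) for cytotoxicity, read by MTT assay, with a stated time of 48 h (a lower number here means that less compound is needed, a higher number that more compound is needed for the effect), compound 1 (`O=C(NCCCCCCCn1cc(-c2ccc[n+]([O-])c2)nn1)c1ccccc1-c1ccccc1`) stands as "not determined" (no result reported) and offers no number for comparison. Going by the values given here, compound 2 (`O=C(NCCCCCCCn1cc(-c2cccnc2)nn1)c1ccccc1-c1cccnc1`) at 36.5 nM therefore holds the only measured value, and it cannot yet be ranked against another compound. Compound 3 (`O=C(NCCCCCCCn1cc(-c2cccnc2)nn1)c1ccccc1-n1cc(CN2CCCCC2)nn1`) remains unmeasured. It has 4-((piperidin-1-yl)methyl)-1H-1,2,3-triazol-1-yl in place of pyridin-3-yl on an aromatic carbon. Among the compounds with values here, no measured pair shows the effect of such a replacement, so the expectation rests on the structural change alone and is uncertain. A moderate move beyond the scatter towards a higher number is expected, meaning that more compound would be needed for the effect. The estimated step is a 4.1-fold higher number from compound 2 to compound 3 (0.61 log units; beyond the scatter) in size. For compound 3 an estimated 150 nM is expected (range 20 nM to 1500 nM).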

Compound 3, half-maximal effective concentration: > 500 nM
Compound 3 gave a limit, no number; the forecaster's own chance of this, stated with the estimate: 10%; at least 3.3-fold (0.52 log units) between middle value and limit.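

Going by these compounds alone, the first measured pair in this assay shows that this position, on an aromatic carbon of a six-membered aromatic ring of carbon only, ortho to a large group, is sensitive to the change: 4-((piperidin-1-yl)methyl)-1H-1,2,3-triazol-1-yl in place of pyridin-3-yl gives an at least 13-fold higher number from compound 2 to compound 3 (1.13 log units; beyond the scatter). Compound 3 gives > 500 nM, which is a limit of the assay and not a number, so the printed step marks only the smallest size of the change. The upper end of the data shown is set by this one result: the limit of > 500 nM in this assay, at which 1 of the 3 values shown sits.

The compounds shown leave open how far compound 3 lies beyond its limit, and whether the five-membered aromatic ring or the piperidine ring accounts for the step. An unsubstituted 1H-1,2,3-triazol-1-yl group, or a primary amine in place of the piperidine, would help to separate the two.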